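Working notes: compound 4 amide end-group replacement

The source may report more compounds than this note shows. Statements on the series, on what has been measured and on what is new or still open speak of the compounds shown alone.

Measured so far:
compound 1, `O=C([C@@H]1CCCN(S(=O)(=O)c2ccc(S(=O)(=O)C3CCC3)cc2)C1)N1CCC(F)(F)CC1`, in a functional assay on MIA PaCa-2 cells (Homo sapiens) for inhibition, read by MTT assay, with a stated time of 3 days (a higher number here means a weaker inhibitor, a lower number a stronger inhibitor), gives > 3000 nM, a limit of the assay.
compound 2, `CC(C)S(=O)(=O)c1ccc(S(=O)(=O)N2CCC[C@@H](C(=O)N3CCC(F)(F)CC3)C2)cc1`, in this assay gives > 3000 nM, also a limit.
compound 3, `CCN(CC)S(=O)(=O)c1ccc(S(=O)(=O)N2CCC[C@@H](C(=O)NC3CCOCC3)C2)cc1`, in this assay gives > 10000 nM, again a limit.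

Compound 3 stands at the limit of > 10000 nM in this assay, at which 1 of the 3 values shown sits, the weaker of the two bounds reported, while compounds 1 and 2 sit at the limit of > 3000 nM in this assay, at which 2 of the 3 values shown sit. Within the data shown here, the one step between measured compounds, a step that the two limits leave unreadable from compound 1 to compound 2, runs between two limits and cannot be read.

Compound 4, `CCN(CC)S(=O)(=O)c1ccc(S(=O)(=O)N2CCC[C@@H](C(=O)N3CCS(=O)(=O)CC3)C2)cc1`, differs from compound 3 by 1,1-dioxothiomorpholin-4-yl in place of (oxan-4-yl)amino on a carbonyl carbon. Among the measured compounds shown here, no measured step bears on this change: the single step available, a step that the two limits leave unreadable from compound 1 to compound 2, concerns the group on the sulfonyl sulfur and is itself unreadable. With all three anchors at limits, no direction beyond the scatter can be expected; the estimated step that the limit leaves unreadable from compound 3 to compound 4 is therefore taken as flat. Compound 4 is expected to remain at or near a limit, with an estimate of 12000 nM and a range of 3000 nM to 40000 nM.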

Compound 4, half-maximal inhibitory concentration: > 10000 nM
Compound 4 was reported as a limit; the forecaster's own chance of this, stated with the estimate: 85%; the middle value lies beyond the limit too.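

In this assay compound 4 gives > 10000 nM as a limit of the assay; compound 3 is also reported as a limit, so no step can be read between the two. The compounds shown leave open how the 1,1-dioxothiomorpholin-4-yl and (oxan-4-yl)amino groups compare in this assay on the shared core.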